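The source may hold more compounds than are shown below. What is called first, only, known or untested is meant among the compounds shown, and "the series" means these compounds.

Among the measured compounds shown here, in an ADME assay on HUVEC cells (Homo sapiens) for cytotoxicity, read by MTT assay, with a stated time of 72 h (a lower number here means a stronger inhibitor, a higher number a weaker inhibitor), compound 1 `O=C(O)CCC(=O)OCCCCCCSc1ccc([N+](=O)[O-])c2nonc12` gives 740 nM and compound 2 `Cc1ccccc1NC(=O)CCC(=O)OCCCCCCSc1ccc([N+](=O)[O-])c2nonc12` gives 1410 nM as the only two measured values. Compound 2 therefore stands within the scatter of compound 1. Compound 3 `O=C(CCC(=O)OCCCCCCSc1ccc([N+](=O)[O-])c2nonc12)Nc1cccc(Cl)c1` differs from compound 2 in one place: 3-chlorophenyl in place of 2-methylphenyl on an amide-type nitrogen with 3-chlorophenyl in place of 2-methylphenyl on an amide-type nitrogen. For the measured compounds named here, the one measured step that bears on this is a 1.9-fold higher number from compound 1 to compound 2 (0.28 log units; within the scatter) for (2-methylphenyl)amino in place of hydroxy on a carbonyl carbon, and it stayed within the scatter. Going by the values given here, no measured step varies the group on the amide-type nitrogen directly, so no shift beyond the scatter is expected in this assay in either direction. For compound 3 the estimated value is 1200 nM with an expected range from 550 nM to 2600 nM in this assay. That estimate means an expected 1.2-fold lower number from compound 2 to compound 3 (0.07 log units; within the scatter) at most within the usual scatter.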

Compound 3, half-maximal inhibitory concentration: 1090 nM
Beside the measured number, compound 3's estimate is 1.1-fold (0.04 log units) above it, within the range that was stated.
By their numbers in this assay, from the lowest: compounds 1, 3 and 2 (each within the scatter of the next).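

In this assay, among the compounds shown here, the change to 3-chlorophenyl in place of 2-methylphenyl on the amide-type nitrogen gives a 1.3-fold lower number from compound 2 to compound 3 (0.11 log units; within the scatter) and is the first measured change to the aryl group at this position, where the two groups have the same heavy-atom count but differ in their substituent and its place on the ring. With (3-chlorophenyl)amino in place of hydroxy on the carbonyl carbon, the piece records a 1.5-fold higher number from compound 1 to compound 3 (0.17 log units; within the scatter) and thus a second aryl amide within the scatter of the carboxylic acid compound 1. Nothing available explains these numbers or links them to any property of the groups.

Because the substituent and its place change together from compound 2 to compound 3, their contributions cannot be separated. Going by these compounds, it also remains open whether this flat picture would hold for a benzyl group, a pyridine ring or a chain ending in an amine on that nitrogen.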